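Methyl in place of hydrogen on compound 1

A few compounds are considered here, and "the series" means these few. Any claim that something is new, unique, unknown or untested is made for them only; others in the source may bear on it.

For the measured compounds named here, compound 1 `Fc1cccc(-c2nc(Nc3ccccc3)c3cc(F)ccc3n2)c1` holds the only number in this set: in a functional assay on U2OS cells (Homo sapiens) for cytotoxicity, read by MTT assay, with a stated time of 48 h (on this read-out lower numbers stand for stronger inhibition and higher numbers for weaker inhibition), compound 1 gives 47600 nM. Compound 2 `Oc1ccc(Nc2nc(-c3cccc(F)c3)nc3ccc(F)cc23)cc1` is the other member, and in this assay compound 2 reaches the limit > 50000 nM rather than a number. Going by the values given here, the one measured step, an at least 1.0-fold higher number from compound 1 to compound 2 (0.02 log units; that floor lies within the scatter), differs from the change toward compound 3 `Cc1cccc(Nc2nc(-c3cccc(F)c3)nc3ccc(F)cc23)c1`, which is methyl in place of hydrogen on an aromatic carbon. Among the compounds with values here, only that step is available, and it lies within the scatter, so no step beyond the scatter is expected in this assay, in either direction. Compound 3 is therefore estimated at 45000 nM, between 20000 nM and 100000 nM, an expected step of a 1.1-fold lower number from compound 1 to compound 3 (0.02 log units; within the scatter).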

Compound 3, half-maximal inhibitory concentration: > 50000 nM
Compound 3: no number, only a limit; the forecaster's own chance of this, stated with the estimate: 45%; at least 1.1-fold (0.04 log units) between middle value and limit.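

Compound 3 gives only a limit of this assay, not a number, so the change to 3-methylphenyl can be read only as an at least 1.0-fold higher number from compound 1 to compound 3 (0.02 log units; that floor lies within the scatter). The step between compound 2 and compound 3 cannot be read, since both stand at a limit. With methyl as with hydroxy on this ring, the read-out gives no number to compare, and the set now gathers at one value: the limit of > 50000 nM in this assay, at which 2 of the 3 values shown sit.

From the compounds shown here alone, the true size of the methyl step remains open. So does the outcome of an amine or a carboxylic acid on this ring.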